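A few compounds are considered here, and "the series" means these few. Any claim that something is new, unique, unknown or untested is made for them only; others in the source may bear on it.

Compound 1 `CC(C)NC(=O)[C@H]1CC[C@@H](n2/c(=N/C(=O)c3ccc(F)c(F)c3)[nH]c3ccc(CN4CCC(C(C)(C)O)CC4)cc32)CC1`: 19 mL.min-1.g-1
Compound 2 `CC(C)NC(=O)[C@H]1CC[C@@H](n2/c(=N/C(=O)c3ccncc3)[nH]c3ccc(CN4CCC(C(C)(C)O)CC4)cc32)CC1`: < 14 mL.min-1.g-1

In an in vitro ADME assay on microsomes from liver (Rattus norvegicus) for metabolic stability (on this read-out higher numbers stand for fast clearance and lower numbers for slow clearance), compound 2 stands at < 14 mL.min-1.g-1, which is a limit of the assay and not a number. Compound 3 `CC(C)NC(=O)[C@H]1CC[C@@H](n2/c(=N/C(=O)c3cc(F)cc(C#N)c3)[nH]c3ccc(CN4CCC(C(C)(C)O)CC4)cc32)CC1` is still to be measured and differs from it as follows: 3-cyano-5-fluorophenyl in place of pyridin-4-yl on a carbonyl carbon. For the measured compounds named here, only one measured step bears on this change: an at least 1.3-fold lower number from compound 1 to compound 2 (0.13 log units; that floor lies within the scatter), with pyridin-4-yl in place of 3,4-difluorophenyl on a carbonyl carbon. Compound 3 also gives up pyridin-4-yl for a phenyl carrying fluorine, so it is expected to fall near compound 1, which gives 19 mL.min-1.g-1. The expected step is therefore a modest rise, an at least 1.2-fold higher number from compound 2 to compound 3 (0.10 log units; that floor lies within the scatter), which may not exceed the scatter. For compound 3 the estimated clearance is 18 mL.min-1.g-1, with an expected range of 9 mL.min-1.g-1 to 36 mL.min-1.g-1.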

Compound 3, intrinsic clearance in microsomes: 30 mL.min-1.g-1
Beside the measured number, compound 3's estimate is 1.7-fold (0.22 log units) below it, within the range that was stated.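

For the compounds shown here, replacing pyridin-4-yl with 3-cyano-5-fluorophenyl on a carbonyl carbon gives, in this assay, the first step at this position that is beyond the scatter: an at least 2.1-fold higher number from compound 2 to compound 3 (0.33 log units; beyond the scatter). Compound 2 is held at a limit of the assay and not a number, so this step is only a floor: the limit of < 14 mL.min-1.g-1 in this assay, at which 1 of the 3 values shown sits. Set against 3,4-difluorophenyl, the 3-cyano-5-fluorophenyl group on the same carbonyl carbon gives a 1.6-fold higher number from compound 1 to compound 3 (0.20 log units; within the scatter), so this read-out does not separate the two fluorinated phenyl groups.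

As far as these compounds go, how far the true value of compound 2 lies under its limit stays open, and with it the full size of the step to pyridin-4-yl. Also open, from the compounds shown here alone, is whether a pyrimidin-4-yl ring or a phenyl ring carrying only a nitrile on this carbonyl carbon would read like pyridin-4-yl or like the fluorinated phenyl groups.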